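A few compounds are considered here, and "the series" means these few. Any claim that something is new, unique, unknown or untested is made for them only; others in the source may bear on it.

Going by the values given here, compound 2 `Cc1c(C=O)cc(-c2ccc(S(C)(=O)=O)cc2)n1-c1ccc(F)c(F)c1` is the only compound here with a measured number: in a functional assay on the whole organism (strain Swiss albino) for inhibition, with Mus musculus as the target, in the writhing test, with a stated time of 30 min, at a dose of 40 mg/kg by the oral route (a higher number here means a stronger effect of the compound at the dose given, a lower number a weaker effect), compound 2 gives 60%. Compound 1 `Cc1c(C=O)cc(-c2ccc(S(C)(=O)=O)cc2)n1-c1cccc(F)c1` has no result reported: in this assay compound 1 gives "not determined" (no result reported), so compound 2 stands alone among the numbers. Compound 3 `Cc1c(C=O)cc(-c2ccc(S(C)(=O)=O)cc2)n1-c1ccccc1` differs from compound 2 by a single change: phenyl in place of 3,4-difluorophenyl on an aromatic nitrogen. Among the compounds with values here, no step between two measured compounds is known, so nothing shows how such a change moves the read-out in this assay. For this change the expected step is a number 10 percentage points lower from compound 2 to compound 3 (within the scatter), a small drop that is not expected to go beyond the usual scatter. Compound 3 is expected to give 50%, in a range from 25% to 70%.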

Compound 3, a percentage reported as inhibition, in the whole organism at one dose (the size of the read-out at that dose, not a potency): 30%
For compound 3 the middle estimate is 20 percentage points above the measured one; low and high end bracket the measured number.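

Replacing 3,4-difluorophenyl with phenyl on the aromatic nitrogen gives, in this assay, a number 30 percentage points lower from compound 2 to compound 3 (beyond the scatter). Going by these compounds alone, this shows that the read-out at this position responds to a change as small as losing the two fluorines from the ring, a point no earlier pair could show. Nothing available explains why the read-out falls.

From the compounds shown here alone, whether both fluorines are needed, or one alone would hold the effect, stays open. So does how a chlorine atom, a methoxy group or an amine on this phenyl ring would behave.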